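Dimethylamino for Hydroxy: Two Cores, One Change

The source may hold more compounds than are shown below. What is called first, only, known or untested is meant among the compounds shown, and "the series" means these compounds.

Measured compounds:
Compound 1, `COc1cc(/C=C/C(=O)c2cccc(N(C)C)c2)cc(OC)c1`: in a functional assay (Homo sapiens) for inhibition (a higher number here means a weaker inhibitor, a lower number a stronger inhibitor), compound 1 gives 5000 nM.
Compound 2, `COc1cc(/C=C/C(=O)c2cccc(O)c2)cc(OC)c1`: in this assay compound 2 gives 3200 nM.
Compound 3, `O=C(/C=C/c1ccc(O)cc1)c1ccc(O)cc1`: in this assay compound 3 gives 59000 nM.

Compound 3 gives the highest of the three numbers, and compound 1 and compound 2 both lie well below it. Compound 1 and compound 2 differ in one place: dimethylamino in place of hydroxy on an aromatic carbon. That step amounts to a 1.6-fold higher number from compound 2 to compound 1 (0.19 log units; within the scatter). Compound 4, `CN(C)c1ccc(/C=C/C(=O)c2ccc(O)cc2)cc1`, has not yet been measured. It differs from compound 3 by the same kind of change: dimethylamino in place of hydroxy on an aromatic carbon. The place, however, is not the same word for word: in compound 1 the group sits meta to a large group, in compound 4 para to a large group. How the core of compound 3 differs from the core of compound 2 is not broken down here. Resting on the step from compound 2 to compound 1, a small step of similar size is expected from compound 3 to compound 4 in this assay, namely a 1.1-fold lower number from compound 3 to compound 4 (0.03 log units; within the scatter). For compound 4 the estimate is 55000 nM, expected to fall between 18000 nM and 170000 nM.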

Compound 4, half-maximal inhibitory concentration: 130000 nM
Compound 4: the middle estimate sits 2.4-fold (0.37 log units) below what was measured, and the stated range covers the measured number.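

On the core of compound 3, dimethylamino in place of hydroxy gives a 2.2-fold higher number from compound 3 to compound 4 (0.34 log units; beyond the scatter) in this assay and so counts as a modest step. Set beside the step on the core of compound 2, the change carries over to the second core with no difference that can be told apart from the scatter: the same change on two cores in this assay, a 1.6-fold higher number (0.19 log units; within the scatter) from compound 2 to compound 1 and a 2.2-fold higher number (0.34 log units; beyond the scatter) from compound 3 to compound 4, 1.4-fold (0.15 log units) apart, within the scatter of two such steps. Among the compounds shown here, this agreement rests on only two pairs, and the group does not stand in the same place in both, being para to a large group only in compound 4, so it neither separates the part played by the core from that played by the place nor shows that the step would hold on any further core.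

The compounds shown leave open whether a primary amine, a methoxy group or a carboxylic acid in place of hydroxy would give a step of similar size on either core. They also leave open how dimethylamino para to a large group would behave on the core of compound 2.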